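An Amide in Place of the Trifluoromethylpyridine

The compounds below may be only part of what the source reports. "The series", "measured", "known", "first", "only" and "open" are said of these compounds alone.

Of the compounds shown here, three sharing one core have been measured in a functional assay on Mahlavu cells (Homo sapiens) for antiproliferative activity, read by sulforhodamine B assay, with a stated time of 72 h; on this read-out lower numbers stand for stronger inhibition and higher numbers for weaker inhibition. Compound 1 `Cc1cc(C)cc(COc2ccc(-c3cc(CN4CCN(Cc5ccc(C(F)(F)F)cc5)CC4)no3)cc2)c1` gives 6000 nM. For the measured compounds named here, compound 2 `Fc1ccccc1COc1ccc(-c2cc(CN3CCN(Cc4ccc(C(F)(F)F)cc4)CC3)no2)cc1` gives 3100 nM, and the one measured step, a 1.9-fold lower number from compound 1 to compound 2 (0.29 log units; within the scatter), sits on the saturated chain carbon bound to an oxygen on an aromatic ring. Compound 3 `N#Cc1cccc(COc2ccc(-c3cc(CN4CCN(c5ccc(C(F)(F)F)cn5)CC4)no3)cc2)c1` gives 1300 nM, the lowest of the three numbers; compound 2 is nearest and compound 1 furthest, both beyond the scatter. Compound 4 `N#Cc1cccc(COc2ccc(-c3cc(CN4CCN(C(=O)C5CCCO5)CC4)no3)cc2)c1` carries (oxolan-2-yl)carbonyl in place of 5-(trifluoromethyl)pyridin-2-yl on an amine nitrogen in a ring. No measured step touches the amine nitrogen in the ring, and the only measured step was within the scatter, so nothing shown predicts this change. Compound 4 is nonetheless expected to move toward a higher number, by a 2.7-fold higher number from compound 3 to compound 4 (0.43 log units; beyond the scatter). Compound 4 is therefore estimated at 3500 nM, between 1200 nM and 12000 nM.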

Compound 4, half-maximal inhibitory concentration: 4100 nM
For compound 4 the middle estimate is 1.2-fold (0.07 log units) below the measured one; low and high end bracket the measured number.
By their numbers in this assay, from the lowest: compound 3; then compounds 2, 4 and 1 (each within the scatter of the next).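

In this assay, for the compounds shown here, the first measured change on the amine nitrogen in the ring, (oxolan-2-yl)carbonyl in place of 5-(trifluoromethyl)pyridin-2-yl, gives a 3.2-fold higher number from compound 3 to compound 4 (0.50 log units; beyond the scatter) and so shows that this position responds to what it carries. The step is modest, although the entering group has no aromatic ring. No measurement shown accounts for the step.

The compounds shown leave open which part of the change carries the step: the carbonyl, the oxolane ring or the loss of trifluoromethyl. A plain pyridin-2-yl or an acetyl group on the same amine nitrogen would separate these.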